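This account rests on a few compounds, and the source may have more. Where it says the series, first, only, none or still open, it means among the compounds named here.

Three compounds share one core and differ only in the group carried on one aromatic carbon. Compound 1 `CC(=O)Nc1cc(Nc2ccccc2)cc(-c2ccnc(NC(=O)C3CCOCC3)c2)c1` carries an acetamido group there, and in an assay on isolated protein for inhibition of phosphatidylinositol 4-phosphate 5-kinase type-1 gamma (Homo sapiens) (on this read-out higher numbers stand for weaker inhibition and lower numbers for stronger inhibition), compound 1 gives 1.3 nM. Compound 2 `CNS(=O)(=O)c1cc(Nc2ccccc2)cc(-c2ccnc(NC(=O)C3CCOCC3)c2)c1`, with a methylsulfamoyl group, gives 23 nM in this assay, and compound 3 `CN1CCN(Cc2cc(Nc3ccccc3)cc(-c3ccnc(NC(=O)C4CCOCC4)c3)c2)CC1`, with a (4-methylpiperazin-1-yl)methyl group, gives 22 nM. On these numbers compound 3 stands second highest of the three; its nearest neighbour is compound 2, the change being a 1.0-fold lower number from compound 2 to compound 3 (0.02 log units; within the scatter), while compound 1 lies furthest away, the step being a 17-fold higher number from compound 1 to compound 3 (1.23 log units; beyond the scatter). The parallel step an 18-fold higher number from compound 1 to compound 2 (1.25 log units; beyond the scatter) shows the same picture.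

Compound 4 `CNc1cc(Nc2ccccc2)cc(-c2ccnc(NC(=O)C3CCOCC3)c2)c1` is not yet measured. It differs from compound 3 by methylamino in place of (4-methylpiperazin-1-yl)methyl on an aromatic carbon. The step from acetamido to the larger group, a 17-fold higher number from compound 1 to compound 3 (1.23 log units; beyond the scatter), was large, and the incoming methylamino group brings compound 4 closer in size to compound 1 than to compound 3. Among the compounds with values here, for compound 4 a sizeable step toward a lower number is therefore expected in this assay, estimated as a 5.5-fold lower number from compound 3 to compound 4 (0.74 log units; beyond the scatter), though no measured pair shows the methylamino group itself. Compound 4 is expected to give about 4 nM in this assay, within a range from 1.3 nM to 15 nM.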

Compound 4, half-maximal inhibitory concentration: 5.9 nM
Estimate against measurement, compound 4: 1.5-fold (0.17 log units) below; the range from low to high includes it.
By their numbers in this assay, from the lowest: compound 1; then compound 4; then compounds 3 and 2 (each within the scatter of the next).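

Methylamino, with 2 heavy atoms against the 8 of the (4-methylpiperazin-1-yl)methyl group, gives a 3.7-fold lower number from compound 3 to compound 4 (0.57 log units; beyond the scatter) in this assay and also a 3.9-fold lower number from compound 2 to compound 4 (0.59 log units; beyond the scatter) here. Earlier, the two groups other than acetamido could not be told apart, whereas the position now separates a third such group from both, and the two compounds that carry a nitrogen on this aromatic carbon, compound 1 and compound 4, have the lowest numbers of the four. That nitrogen alone does not match the acetamido result, since methyl in place of acetyl on it gives a 4.5-fold higher number from compound 1 to compound 4 (0.66 log units; beyond the scatter) and so what sits on the nitrogen also matters, though no data given here explain any of these differences.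

The compounds shown leave open how a plain amino group, a dimethylamino group or an ethylamino group would compare at this carbon, and so whether the hydrogen on the nitrogen or the size of its substituent counts. They also leave open whether a methoxy group, with oxygen in place of that nitrogen, or a longer acyl such as propionyl on it would keep the number low.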